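Varying the Group Beside a Pyrazole Acid Core

The compounds below may be only part of what the source reports. "The series", "measured", "known", "first", "only" and "open" are said of these compounds alone.

Measured compounds:
compound 1 `Cc1n[nH]c(C(=O)O)c1Cc1cccc(-c2cccc(F)c2)c1`, 500 nM
compound 2 `Cc1n[nH]c(C(=O)O)c1Cc1cccc(-c2ccccc2F)c1`, 900 nM
compound 3 `Cc1n[nH]c(C(=O)O)c1Cc1cccc(C#N)c1`, 500 nM

Of the compounds shown here, three sharing one core have been measured in an assay on isolated protein for inhibition of 2-Hydroxyacid oxidase 2 (Rattus norvegicus); on this read-out higher numbers stand for weaker inhibition and lower numbers for stronger inhibition. Compound 3 gives 500 nM, level with compound 1 at the digits shown, and together these two are the lowest numbers of the set; compound 2 is furthest from it, yet a 1.8-fold lower number from compound 2 to compound 3 (0.26 log units; within the scatter), so all three sit within the scatter of one another.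

The next compound, compound 4 `Cc1n[nH]c(C(=O)O)c1Cc1cccc(OC(F)(F)F)c1`, is not yet measured. It differs from compound 3 in one place: trifluoromethoxy in place of cyano on an aromatic carbon. Among the measured compounds shown here, two measured steps bear on this position. From compound 1 to compound 3 there was no change at the digits printed from compound 1 to compound 3 (within the scatter), and a 1.8-fold lower number from compound 2 to compound 3 (0.26 log units; within the scatter). Both show that exchanging the group at this aromatic carbon, even between groups of quite different size, moved the number little. On that basis the expected step in this assay from compound 3 to compound 4 is small, in no particular direction, and is unlikely to exceed the scatter.

Compound 4 is therefore estimated at 500 nM, within a range from 200 nM to 1500 nM, which means an expected step of no change at the digits printed from compound 3 to compound 4 (within the scatter).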

Compound 4, half-maximal inhibitory concentration: 700 nM
The estimate for compound 4 lay 1.4-fold (0.15 log units) below the measured number; the range from low to high includes it.
By their numbers in this assay, from the lowest: compounds 1, 3, 4 and 2 (each within the scatter of the next).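

In this assay, the move to trifluoromethoxy gives a 1.4-fold higher number from compound 3 to compound 4 (0.15 log units; within the scatter), so a group with 5 heavy atoms, bringing oxygen and fluorine to this aromatic carbon, stays within the scatter of the cyano group with its 2 heavy atoms. Set against the two fluorophenyl groups, the same group gives a 1.3-fold lower number from compound 2 to compound 4 (0.11 log units; within the scatter) and a 1.4-fold higher number from compound 1 to compound 4 (0.15 log units; within the scatter), which means that all four compounds, with or without a second ring at this place, now lie within the scatter of one another, and none goes against that pattern. Nothing measured here accounts for this flat response, and no supporting data on the change are at hand.

From the compounds shown here alone, whether an amine, a hydroxyl or a carboxylic acid on this aromatic carbon would stay within the same scatter remains open, as does the effect of a longer chain at this place. The compounds shown also leave open what happens away from this aromatic carbon, for instance with an ethyl group in place of the methyl on the shared core, or with an amide in place of its carboxylic acid.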